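A few compounds are considered here, and "the series" means these few. Any claim that something is new, unique, unknown or untested is made for them only; others in the source may bear on it.

In a functional assay on PC-3 cells (Homo sapiens) for cytotoxicity, read by MTT assay, with a stated time of 72 h (a higher number here means a weaker inhibitor, a lower number a stronger inhibitor), compound 1 `CC1=C(/C=C/C(=O)/C=C/c2ccccc2)C(C)(C)CCC1O` gives 15500 nM. Among the measured compounds shown here, only one other compound offers a comparison: compound 2 `CC1=C(/C=C/C(=O)/C=C/c2ccc(C(F)(F)F)cc2)C(C)(C)CCC1O` gives 10200 nM. For the measured compounds named here, the two values lie within the scatter of each other, so compound 1 cannot be ranked against its single neighbour. The step followed here leads to compound 3 `CC1=C(/C=C/C(=O)/C=C/c2cccc(C#N)c2)C(C)(C)CCC1O`, which has not yet been measured. The change is cyano in place of hydrogen on an aromatic carbon, with cyano in place of hydrogen on an aromatic carbon, meta to a large group. Going by the values given here, one measured step bears on it, as it also replaces hydrogen on an aromatic carbon: trifluoromethyl in place of that hydrogen gives a 1.5-fold lower number from compound 1 to compound 2 (0.18 log units; within the scatter). That step stays within the scatter, but it involves a different group, and a single step is thin evidence. No shift beyond the scatter, in either direction, is therefore expected in this assay. The expected outcome is a 1.2-fold lower number from compound 1 to compound 3 (0.09 log units; within the scatter), which is an estimate and not a measurement. Compound 3 is estimated at 12500 nM, with an expected range from 6500 nM to 24000 nM.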

Compound 3, half-maximal inhibitory concentration: 7200 nM
The estimate for compound 3 lay 1.7-fold (0.24 log units) above the measured number; measured number inside the range.
By their numbers in this assay, from the lowest: compounds 3, 2 and 1 (each within the scatter of the next, the first and the last beyond it).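

In this assay cyano in place of hydrogen on an aromatic carbon, meta to a large group, gives a 2.2-fold lower number from compound 1 to compound 3 (0.33 log units; beyond the scatter) and is the only change shown whose step passes the scatter, though only modestly. The earlier step, a 1.5-fold lower number from compound 1 to compound 2 (0.18 log units; within the scatter) with trifluoromethyl, stayed within the scatter, so only now can a replacement on this aromatic ring be said to shift the number, and only for cyano at this place, while compound 2 and compound 3 remain within the scatter of each other and cannot be ranked. No measurement among those available accounts for the shift from hydrogen to cyano.

The compounds shown leave open whether the step belongs to cyano itself, to this place on the ring, or to both, since no other group stands at this place and cyano stands nowhere else on the ring. An amine, a carboxylic acid or a methoxy group at this same place, together with cyano on another aromatic carbon, would separate these possibilities.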